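A few compounds are considered here, and "the series" means these few. Any claim that something is new, unique, unknown or untested is made for them only; others in the source may bear on it.

Measured compounds:
- compound 1, `COC/C1=C/C[C@](C)(CCC=C(C)C)/C=C/[C@@H](OC(=O)C=C(C)C)[C@](C)(OC)/C=C/C1=O`: 16500 nM
- compound 2, `CC(C)=CCC[C@]1(C)/C=C/[C@@H](OC(=O)C=C(C)C)[C@](C)(O)/C=C/C(=O)/C(CN(C)C)=C\C1`: 690 nM
- compound 3, `CC(C)=CCC[C@](C)(/C=C/[C@@H](OC(=O)C=C(C)C)[C@](C)(O)/C=C/C(=O)/C=C/N(C)C)CC=O`: 12200 nM

All three numbers come from a functional assay on MCF7 cells (Homo sapiens) for antiproliferative activity, read by MTT assay, with a stated time of 48 h; a higher number here means a weaker inhibitor, a lower number a stronger inhibitor. Compound 2 stands lowest of the three. Compound 3 sits nearest, its number higher than that of compound 2 by a gap that lies beyond the scatter of repeated measurements; compound 1 sits furthest, higher still, also beyond the scatter. No single-point steps between the measured compounds are available, so nothing more than these two comparisons can be read from them, and no cause is given for either gap.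

Compound 4 is `CC(C)=CCC[C@]1(C)/C=C/[C@@H](OC(=O)C=C(C)C)[C@](C)(O)/C=C/C(=O)/C(C(=O)N(C)C)=C\C1`. It differs from compound 2 in one place: dimethylcarbamoyl in place of (dimethylamino)methyl on a double-bonded ring carbon. With no measured step of this kind in the series, the direction and size of the change can only be set as an expectation. The working expectation is a step upward in this assay, that is toward a weaker inhibitor. The expected step is estimated as a 4.3-fold higher number from compound 2 to compound 4 (0.64 log units; beyond the scatter). That size lies beyond the scatter yet well short of the gap separating compound 2 from compound 3. Compound 4 is accordingly estimated at 3000 nM, with an expected range from 900 nM to 12000 nM.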

Compound 4, half-maximal inhibitory concentration: 3670 nM
Compound 4: middle estimate off by 1.2-fold (0.09 log units), on the low side; the measured number falls inside the stated range.
By their numbers in this assay, from the lowest: compound 2; then compound 4; then compounds 3 and 1 (each within the scatter of the next).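

Within the data shown here, the first one-place step concerns the substituent on the double-bonded ring carbon: in this assay, dimethylcarbamoyl in place of (dimethylamino)methyl gives a 5.3-fold higher number from compound 2 to compound 4 (0.73 log units; beyond the scatter), so this position responds to the change by a margin beyond the scatter, toward a weaker inhibitor. The two groups carry the same computed counts of hydrogen-bond donors and acceptors and no net charge, so those counts do not separate them; the entering group differs by one additional oxygen and a double bond outside aromatic rings. No measurement bears on why the number moves, and the step stands without an explanation.

Open, going by these compounds, is how other groups at this ring carbon would fall relative to compound 2 and compound 4, for example a morpholin-4-ylmethyl group, a longer chain between the ring carbon and the dimethylamino nitrogen, or a carboxylic acid. Also open, on these data alone, is whether the same exchange would give a step of similar size with other substituents on the shared core, such as a methoxy group in place of the hydroxy group.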